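The source may hold more compounds than are shown below. What is called first, only, known or untested is meant among the compounds shown, and "the series" means these compounds.

Of the compounds shown here, three sharing one core have been measured in an assay on FRT-Jurkat cells for inhibition of nuclear factor NF-kappa-B complex (Homo sapiens), read by flow cytometry, with a stated time of 24 h, tested at 10 uM; a lower number here means less inhibition, a higher number more inhibition at the concentration tested (going by the name of the read-out). Compound 1, `CC(C)(C)c1ccc(Nc2ccc3c(c2)C(=O)N(C2CCC(=O)NC2=O)C3=O)cc1`, gives 17%. Compound 2, `CCCCCc1ccc(Nc2ccc3c(c2)C(=O)N(C2CCC(=O)NC2=O)C3=O)cc1`, gives 12%, and compound 3, `CC(C)c1ccc(Nc2ccc3c(c2)C(=O)N(C2CCC(=O)NC2=O)C3=O)cc1`, gives 11%. Compound 3 thus holds the lowest of the three numbers, yet its distance to the others is small: the step of a number 6 percentage points lower from compound 1 to compound 3 (within the scatter) and the step of a number 1 percentage points lower from compound 2 to compound 3 (within the scatter) both lie within the scatter, as does the step of a number 5 percentage points lower from compound 1 to compound 2 (within the scatter).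

Compound 4, `CC(=O)c1ccc(Nc2ccc3c(c2)C(=O)N(C2CCC(=O)NC2=O)C3=O)cc1`, differs from compound 3 by acetyl in place of isopropyl on an aromatic carbon. The group that enters, acetyl, brings one hydrogen-bond acceptor and a double bond outside aromatic rings, where isopropyl brought neither.

Among the compounds with values here, the three measured steps each swap one alkyl group for another, and none moves the read-out beyond the scatter; no measured step covers an acetyl group, so these small alkyl swaps are the only guide. On that basis, no step beyond the scatter is expected in this assay. Compound 4 is expected to give about 12%, with a range from 2% to 25%. This estimate corresponds to an expected step of a number 1 percentage points higher from compound 3 to compound 4 (within the scatter).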

Compound 4, a percentage reported as inhibition, at one concentration (the size of the read-out at that concentration, not a potency): -2%
Compound 4: the middle estimate sits 14 percentage points above what was measured, outside the stated range (below it).
By their numbers in this assay, from the lowest: compound 4; then compounds 3, 2 and 1 (each within the scatter of the next).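

Within the data shown here, the aromatic carbon para to a large group is not indifferent to what it carries in this assay: swaps among alkyl groups stayed within the scatter, but acetyl gives the first steps beyond it (a number 13 percentage points lower from compound 3 to compound 4 (beyond the scatter); a number 14 percentage points lower from compound 2 to compound 4 (beyond the scatter); a number 19 percentage points lower from compound 1 to compound 4 (beyond the scatter)). Acetyl has the same heavy-atom count as isopropyl, so the step from isopropyl comes with no added size by that count, only with an oxygen in place of a carbon, a double bond and a hydrogen-bond acceptor. Nothing at hand shows which of these features matters or why the number falls.

Among these compounds, compound 4 is the only compound here without an alkyl group at this position, so the change rests on a single example. Going by these compounds, whether a methoxy group, an amine or a carboxylic acid at this position would also give a lower number remains open.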